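The compounds below may be only part of what the source reports. "The series", "measured", "known", "first", "only" and "open" are said of these compounds alone.

Of the compounds shown here, three sharing one core have been measured in a functional assay on HUVEC cells (Homo sapiens) for inhibition, with a stated time of 4 days; on this read-out higher numbers stand for weaker inhibition and lower numbers for stronger inhibition. Compound 1 `COc1ccc(C(N)=O)cc1/C=C/c1ccc(C)cc1` gives 1600 nM in this assay. Compound 2 `COc1ccc(C(N)=O)cc1/C=C/c1ccc(F)cc1` gives 2100 nM in this assay. Compound 3 `COc1ccc(C(N)=O)cc1/C=C/c1ccccc1F` gives 2000 nM in this assay. All three numbers lie close together, and none of the differences between them goes beyond the usual scatter of repeated measurements.

Compound 2 and compound 1 differ by a single change, (methyl in place of fluoro on an aromatic carbon). This change gave a 1.3-fold lower number from compound 2 to compound 1 (0.12 log units; within the scatter), a step too small to count as a real shift.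

Compound 3 and compound 2 contain the same atoms joined differently; the difference between the two cores is not broken down here.

Compound 4 `COc1ccc(C(N)=O)cc1/C=C/c1ccccc1C` has not yet been measured in this assay. It differs from compound 3 by methyl in place of fluoro on an aromatic carbon. This is the same kind of change as that from compound 2 to compound 1, but not the same: in compound 1 the methyl sits para to a large group, while in compound 4 it sits ortho to a large group.

Because the earlier step was a 1.3-fold lower number from compound 2 to compound 1 (0.12 log units; within the scatter), the expected step here is a 1.3-fold lower number from compound 3 to compound 4 (0.10 log units; within the scatter), with the different surroundings of the group leaving extra room for error. Compound 4 is therefore estimated at 1600 nM in this assay, expected to fall between 800 nM and 3200 nM.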

Compound 4, half-maximal inhibitory concentration: 2300 nM
The estimate for compound 4 lay 1.4-fold (0.16 log units) below the measured number; low and high end bracket the measured number.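

In this assay, putting methyl in place of fluoro gave a 1.2-fold higher number from compound 3 to compound 4 (0.06 log units; within the scatter), a step too small to count as a real shift. Set beside the earlier case of the same swap, this step does not differ from it by more than repeated measurements of this kind would: the same change on two cores in this assay, a 1.3-fold lower number (0.12 log units; within the scatter) from compound 2 to compound 1 and a 1.2-fold higher number (0.06 log units; within the scatter) from compound 3 to compound 4, 1.5-fold (0.18 log units) apart, within the scatter of two such steps. Across these two pairs, then, the swap carries from one core to the other in the plain sense that it leaves the number essentially unchanged on both, even though the methyl of compound 4 sits ortho to a large group; this does not show that the swap has no effect on any other core, and two steps this small cannot reveal a modest difference between the cores.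

All four compounds carry only methyl or fluoro on that ring, so the series as shown cannot tell whether a clearly different group, such as an amine, a carboxylic acid or a longer chain, would move the number beyond the scatter. As far as these compounds go, it also remains open whether the swap would behave in the same way on a core further removed from these two, or in a different kind of assay.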